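The source may hold more compounds than are shown below. What is called first, only, known or untested is meant among the compounds shown, and "the series" means these compounds.

Measured so far, in a functional assay on the whole organism (Tail, strain ICR) with Mus musculus as the target, in the tail flick test, with a stated time of 150 min, at a dose of 25 umol/kg by the oral route; on this read-out higher numbers stand for a stronger effect at the one dose given and lower numbers for a weaker effect:
Compound 1, `O=C(CN(c1nc(Cl)nc2[nH]cnc12)C1CC1)N[C@@H](CO)C(=O)O`, gives 18.8%.
Compound 2, `O=C(O)CNC(=O)CN(c1nc(Cl)nc2[nH]cnc12)C1CC1`, gives 9.08%.
Compound 3, `CC(C)[C@H](NC(=O)CN(c1nc(Cl)nc2[nH]cnc12)C1CC1)C(=O)O`, gives 7.86%.

On these three numbers compound 3 stands at the bottom. Its distance to compound 2 is the step of a number 1.2 percentage points lower from compound 2 to compound 3 (within the scatter), and its distance to compound 1 is the step of a number 10.9 percentage points lower from compound 1 to compound 3 (beyond the scatter), the only one of the three that reaches beyond the scatter.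

Compound 4, `CC(C)C[C@H](NC(=O)CN(c1nc(Cl)nc2[nH]cnc12)C1CC1)C(=O)O`, differs from compound 3 in one place: isobutyl in place of isopropyl on a saturated chain carbon bound to an amide-type nitrogen and a carbonyl carbon. The step that bears most directly on this is a number 1.2 percentage points lower from compound 2 to compound 3 (within the scatter), which altered the same saturated chain carbon and stayed within the scatter. The step of a number 9.7 percentage points lower from compound 1 to compound 2 (within the scatter) at that carbon also stayed within the scatter; only a number 10.9 percentage points lower from compound 1 to compound 3 (beyond the scatter) went modestly beyond it. The present change is smaller than any of those, one carbon added to a group already in place, so one expects no step beyond the scatter in this assay, that is, an expected step of a number 1.1 percentage points higher from compound 3 to compound 4 (within the scatter). Compound 4 is therefore estimated to give 9% in this assay, with an expected range from 0% to 20%.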

Compound 4, a percentage reported as activity, at one dose (the size of the read-out at that dose, not a potency): 9.13%
Beside the measured number, compound 4's estimate is 0.1 percentage points below it; the range from low to high includes it.
By their numbers in this assay, from the lowest: compounds 3, 2, 4 and 1 (each within the scatter of the next, the first and the last beyond it).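

In this assay, the isobutyl group of compound 4 brings a number 1.3 percentage points higher from compound 3 to compound 4 (within the scatter) and a number 0.1 percentage points higher from compound 2 to compound 4 (within the scatter), so at this saturated chain carbon neither the added carbon of isobutyl over isopropyl nor isobutyl in place of hydrogen separates these compounds. Within the data shown here, the step of a number 9.7 percentage points lower from compound 1 to compound 4 (within the scatter) also stays inside the scatter, which leaves a number 10.9 percentage points lower from compound 1 to compound 3 (beyond the scatter) as the only step that goes beyond it, and that by a modest margin. Nothing available explains these results. The compounds shown leave open whether a chain ending in an amine or a carboxylic acid, or a benzyl group, at this carbon would move the number beyond the scatter. They also leave open whether a longer chain than isobutyl would do so.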